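Iodo in Place of Acetyl: Compound 4 Awaits Measurement

The source may report more compounds than this note shows. Statements on the series, on what has been measured and on what is new or still open speak of the compounds shown alone.

Compound 1 `CCN(c1nc(C)nc(N(CC2CC2)CC2CC2)n1)c1ccc(N(C)C)cc1C(F)(F)F`: 5 nM
Compound 2 `CCCCN(CC)c1cc(C)nc(N(CC)c2ccc(C(C)=O)cc2Br)n1`: 8 nM
Compound 3 `CCN(c1nc(C)cc(C)n1)c1c(Br)cc(N(C)C)cc1OC`: 5 nM

Of the compounds shown here, three have so far been measured in an assay on isolated protein for binding affinity to corticotropin-releasing factor receptor 1 (Homo sapiens); on this read-out higher numbers stand for weaker inhibition and lower numbers for stronger inhibition. Compound 2 gives the highest of the three numbers, but its gap to compound 1 and to compound 3 is within the scatter, so nothing in these values sets the three apart.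

Compound 4 `CCCCN(CC)c1cc(C)nc(N(CC)c2ccc(I)cc2Br)n1` has not yet been measured. It differs from compound 2 in one place: iodo in place of acetyl on an aromatic carbon. Within the data shown here, no measured pair shows this exchange, so the data hold no step that anchors it. The three measured compounds carry quite different substituents on their aryl rings and still sit together in this assay, which gives no sign that this position drives large changes. The step is expected to be a 1.3-fold lower number from compound 2 to compound 4 (0.12 log units; within the scatter), no larger than the scatter in either direction. Compound 4 is therefore expected to give 6 nM, with a range from 2 nM to 20 nM.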

Compound 4, inhibition constant: 14 nM
The estimate for compound 4 lay 2.3-fold (0.37 log units) below the measured number, within the range that was stated.
By their numbers in this assay, from the lowest: compounds 1, 3, 2 and 4 (each within the scatter of the next, the first and the last beyond it).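

In this assay, replacing acetyl with iodo on this aromatic carbon, meta to a bromo group and para to a large group, gives a 1.8-fold higher number from compound 2 to compound 4 (0.24 log units; within the scatter). Among these compounds, this is the only measured step at this place, and it gives direct evidence where the earlier compounds offered only a loose comparison across different structures. Acetyl carries a hydrogen-bond acceptor and iodo carries none, yet this exchange does not move the number beyond the scatter. No measurement at hand explains this result.

The compounds shown leave open whether a carboxylic acid, a primary amine or a longer alkyl chain on this carbon would also stay within the scatter of compound 2. They also leave open whether the same exchange would read alike on a compound lacking the bromo group.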